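Trading the Cyclohexyl Ring for Ethoxy on the Amide

This account rests on a few compounds, and the source may have more. Where it says the series, first, only, none or still open, it means among the compounds named here.

Compound 2 `CC1CCCCC1NC(=O)[C@H]1OC(n2cnc3c(N)ncnc32)[C@H](O)[C@@H]1O` is one of two nucleoside amides measured in an assay on cell membranes for binding affinity to 2-oxoglutarate receptor 1 (Rattus norvegicus), read by radioligand binding; a higher number here means a weaker inhibitor, a lower number a stronger inhibitor. Compound 2 gives 69.5 nM in this assay, the higher of the two numbers. Going by the values given here, its only neighbour, compound 1 `CCCCCCCCNC(=O)[C@H]1OC(n2cnc3c(N)ncnc32)[C@H](O)[C@@H]1O`, carries an octyl chain on the same amide-type nitrogen, and in this assay compound 1 gives 21 nM. Among the compounds with values here, the single measured step, a 3.3-fold higher number from compound 1 to compound 2 (0.52 log units; beyond the scatter), shows that exchanging the octyl chain for a 2-methylcyclohexyl ring weakens binding modestly.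

Compound 3 `CCONC(=O)[C@H]1OC(n2cnc3c(N)ncnc32)[C@H](O)[C@@H]1O` has not yet been measured. It differs from compound 2 by ethoxy in place of 2-methylcyclohexyl on an amide-type nitrogen; cut one bond further out, the change reads (2-methylcyclohexyl)amino to ethoxyamino. Within the data shown here, only the step from compound 1 to compound 2 bears on this, and it bears loosely: it shows that the group on the amide nitrogen matters and that a smaller group gave a weaker binder. Among the measured compounds shown here, no measured compound carries an oxygen on this nitrogen, so the direction rests on that single step alone. The expectation is therefore a further weakening, with compound 3 estimated at 300 nM, within 60 nM to 2000 nM, a step of a 4.3-fold higher number from compound 2 to compound 3 (0.64 log units; beyond the scatter) from compound 2 to compound 3.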

Compound 3, inhibition constant: 67 nM
Compound 3: the middle estimate sits 4.5-fold (0.65 log units) above what was measured; the range from low to high includes it.
By their numbers in this assay, from the lowest: compound 1; then compounds 3 and 2 (each within the scatter of the next).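

In this assay, putting ethoxy in place of 2-methylcyclohexyl on the amide-type nitrogen gives a 1.0-fold lower number from compound 2 to compound 3 (0.02 log units; within the scatter), so the two groups cannot be told apart here, even though ethoxy has fewer heavy atoms, no ring and a hydrogen-bond acceptor. Set against the octyl chain, ethoxy gives a 3.2-fold higher number from compound 1 to compound 3 (0.50 log units; beyond the scatter), which places both compound 2 and compound 3 apart from compound 1 and shows that the ring is not needed to reach the level of compound 2 in this series. No measurement shown accounts for why two such different groups read alike at this position.

Going by these compounds, what a propyl chain, a benzyl group or a longer alkoxy group such as octyloxy would give on this nitrogen stays open, as does whether the oxygen of ethoxy has any part in the reading of compound 3. Also open, on these data alone, is whether chain length alone sets compound 1 apart, a question that a hexyl or decyl chain in the same place could address.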